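Methyl to hydrogen on the side-chain oxygen of compound 2

The source may report more compounds than this note shows. Statements on the series, on what has been measured and on what is new or still open speak of the compounds shown alone.

For the measured compounds named here, in a toxicity assay on EA.hy 926 cells (Homo sapiens) for cytotoxicity, read by MTT assay, with a stated time of 48 h (on this read-out lower numbers stand for stronger inhibition and higher numbers for weaker inhibition), compound 2 `COCCNC(=C\C(=O)/C=C/c1ccc(O)cc1)/C=C/c1ccc(O)cc1` gives 45100 nM, the only number in this set. Compound 1 `COCCCN1C(/C=C/c2ccc(O)cc2)=CC(=O)CC1c1ccc(O)cc1` is reported in this assay only as a limit, > 100000 nM, as noted in the limit of > 100000 nM in this assay, at which 1 of the 2 values shown sits. Compound 3 `O=C(/C=C(/C=C/c1ccc(O)cc1)NCCO)/C=C/c1ccc(O)cc1` differs from compound 2 by hydrogen in place of methyl on an oxygen on a saturated carbon; read one bond further out, this is methoxy to hydroxy, or 2-methoxyethyl to 2-hydroxyethyl. Going by the values given here, no step between measured compounds exists to guide the size, so in this assay the change is expected to stay within the scatter, with no clear direction. Compound 3 is therefore estimated at 50000 nM, between 20000 nM and 120000 nM, the expected step being a 1.1-fold higher number from compound 2 to compound 3 (0.04 log units; within the scatter).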

Compound 3, half-maximal inhibitory concentration: 50200 nM
Estimate against measurement, compound 3: 1.0-fold (0.00 log units) below, and the stated range covers the measured number.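

Going from 2-methoxyethyl to 2-hydroxyethyl gives, in this assay, a 1.1-fold higher number from compound 2 to compound 3 (0.05 log units; within the scatter). For the compounds shown here, this is the first readable step, and it shows no separation between methyl and hydrogen on this oxygen. Compound 1 differs from both compounds in more than one place and stands only as a limit of the assay: the limit of > 100000 nM in this assay, at which 1 of the 3 values shown sits.

As far as these compounds go, whether an amine, a carboxylic acid or a longer chain in place of the hydroxy group of compound 3 would move the number beyond the scatter remains open. A single step also leaves open how far this result carries to other changes on the shared core.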